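Acid in Place of Thioether on the Amine Side

The compounds below may be only part of what the source reports. "The series", "measured", "known", "first", "only" and "open" are said of these compounds alone.

Among the measured compounds shown here, compound 2 `CSc1ccc(CNC(=O)c2ccc(C(C)(C)C)cc2)cc1` gives 100 nM in an assay on HeLa cells with Bile acid receptor (Homo sapiens) as the target, read by a luciferase reporter, with a stated time of 24 h (on this read-out lower numbers stand for an effect already at smaller amounts and higher numbers for an effect only at larger amounts of compound), the lower of the two numbers measured so far. Compound 1 `O=C(O)c1ccc(CNC(=O)c2ccc3ccccc3c2)cc1` gives 1360 nM in this assay, a higher number that lies beyond the usual scatter; the two compounds differ in more than one place, so no single step can be read from that pair. Compound 3 `CC(C)(C)c1ccc(C(=O)NCc2ccc(OCC(=O)O)cc2)cc1` has not yet been measured. It keeps the rest of compound 2 and differs from it in one place: carboxymethoxy in place of methylsulfanyl on an aromatic carbon. For the measured compounds named here, no measured pair isolates this change. Going by the values given here, the nearest hint is that compound 1, the only compound here carrying a carboxylic acid, gives 1360 nM, while compound 2 gives 100 nM. Compound 3 is therefore expected to give 500 nM, estimated between 150 nM and 2000 nM, with the expected step of a 5.0-fold higher number from compound 2 to compound 3 (0.70 log units; beyond the scatter) pointing toward a higher number beyond the scatter.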

Compound 3, half-maximal effective concentration: 730 nM
Compound 3: the middle estimate sits 1.5-fold (0.16 log units) below what was measured; the measured number falls inside the stated range.
By their numbers in this assay, from the lowest: compound 2; then compounds 3 and 1 (each within the scatter of the next).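

In this assay, among the compounds shown here, carboxymethoxy in place of methylsulfanyl on an aromatic carbon, para to a large group, gives a 7.3-fold higher number from compound 2 to compound 3 (0.86 log units; beyond the scatter) and is the first step here that isolates a single change. It shows that the number does respond to the group at this place, which the earlier pair, differing in more than one place, could not show. It also shows that a group ending in a carboxylic acid can stand at this place with the effect still measurable, at the price of a modest rise in the number. No measurement here gives a reason for this step.

Still open, going by these compounds, is whether the rise belongs to the carboxylic acid itself or to the ether oxygen and the longer chain, which a methoxy group or a methyl ester at this place would help to separate. Also open, on these data alone, is how an amine or a carboxylic acid set directly on this aromatic carbon would compare with methylsulfanyl.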